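The compounds below may be only part of what the source reports. "The series", "measured", "known", "first", "only" and "open" are said of these compounds alone.

Compound 1 `Cc1cc(NC(=O)Cn2nnc(-c3ccccc3)n2)n(C2CCC(F)(F)CC2)n1` is the starting point of this step. In an assay on HEK293 cells for activation of Kir3.1/Kir3.2 (Homo sapiens), read by thallium flux (on this read-out higher numbers stand for larger maximal responses and lower numbers for smaller maximal responses), compound 1 gives 68%, which is the lowest of the two numbers recorded; the nearest is compound 3 `Cc1cc(NC(=O)Cn2nnc(-c3ccccc3)n2)n(C2CCCC2)n1`, which in this assay gives 105%. The third value recorded is not a number but a limit of the assay, and it belongs to compound 2 `Cc1cc(NC(=O)Cn2nnc(-c3ccccc3)n2)n(C2CC2)n1`, which in this assay reaches only the limit > 78%; this is the situation described by the limit of > 78% in this assay, at which 1 of the 3 values shown sits.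

The compound to be judged is compound 4 `Cc1cc(NC(=O)Cn2nnc(-c3ccccc3)n2)n(CC2CCCCC2)n1`, which differs from compound 1 as follows: cyclohexylmethyl in place of 4,4-difluorocyclohexyl on an aromatic nitrogen. Within the data shown here, two measured steps bear on it, since both also exchange the 4,4-difluorocyclohexyl on the aromatic nitrogen for a different carbocycle. The step of a number at least 10 percentage points higher from compound 1 to compound 2 (that floor lies within the scatter) points upward, although its floor lies within the scatter, and the step of a number 37 percentage points higher from compound 1 to compound 3 (beyond the scatter) is a large rise well beyond the scatter. The step that the limit leaves unreadable from compound 2 to compound 3 cannot be read because of the limit. Both readable directions therefore agree that leaving the 4,4-difluorocyclohexyl raises the maximal response, and for cyclohexylmethyl an upward step is expected, estimated as a number 27 percentage points higher from compound 1 to compound 4 (beyond the scatter). Compound 4 is accordingly expected to give about 95% in this assay, with a likely range from 72% to 118%.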

Compound 4, largest response reached (Emax), in percent of the reference or control that the assay uses: 77%
Beside the measured number, compound 4's estimate is 18 percentage points above it; low and high end bracket the measured number.
By their numbers in this assay, from the lowest: compounds 1 and 4 (each within the scatter of the next); then compound 3.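

At this place on the aromatic nitrogen, cyclohexylmethyl in place of 4,4-difluorocyclohexyl gives in this assay a number 9 percentage points higher from compound 1 to compound 4 (within the scatter), so this exchange, which keeps a six-membered non-aromatic ring of carbon only, does not separate compound 4 from compound 1. Cyclopentyl and cyclohexylmethyl do separate, with a number 28 percentage points lower from compound 3 to compound 4 (beyond the scatter), which shows that the high response of compound 3 is not shared by every group that replaces the 4,4-difluorocyclohexyl, so leaving that group does not by itself secure a clear rise. Compound 2 gives a limit of the assay and not a number, > 78%.

The relation of compound 2 to its neighbours stays unsettled, with only a number at least 1 percentage points lower from compound 2 to compound 4 (that floor lies within the scatter) and its step to compound 3 unreadable: the limit of > 78% in this assay, at which 1 of the 4 values shown sits. The compounds shown also leave open how plain cyclohexyl or cyclopentylmethyl on the same aromatic nitrogen would behave in this assay, and so whether the lower responses of compound 1 and compound 4 go with the six-membered ring they share or with what each carries besides it.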